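This account rests on a few compounds, and the source may have more. Where it says the series, first, only, none or still open, it means among the compounds named here.

Compound 2 `O=C(O)c1cccc(C2CC2c2ccc(OCc3c(-c4c(Cl)cccc4Cl)noc3C3CC3)cc2Cl)c1` gives 102% in an assay on isolated protein for agonist activity at Bile acid receptor (Homo sapiens), read by FRET; a higher number here means a larger maximal response, a lower number a smaller maximal response. Compound 1 `O=C(O)c1ccc(C2CC2c2ccc(OCc3c(-c4c(Cl)cccc4Cl)noc3C3CC3)cc2Cl)cn1` gives 101%, and compound 3 `O=C(O)c1cccc([C@@H]2C[C@H]2c2ccc(OCc3c(-c4c(Cl)cccc4Cl)noc3C3CC3)cc2Cl)c1` gives 100%; the steps of a number 1 percentage points higher from compound 1 to compound 2 (within the scatter) and a number 2 percentage points lower from compound 2 to compound 3 (within the scatter) separate none of the three by more than the usual scatter. The change to compound 4 `Clc1cc(OCc2c(-c3c(Cl)cccc3Cl)noc2C2CC2)ccc1C1CC1c1ccc(-c2nnn[nH]2)nc1` is 6-(1H-tetrazol-5-yl)pyridin-3-yl in place of 3-carboxyphenyl on a saturated ring carbon. Within the data shown here, the measured step that bears on it is a number 1 percentage points higher from compound 1 to compound 2 (within the scatter), which exchanged 3-carboxyphenyl for 6-carboxypyridin-3-yl without moving the read-out; no measured step exchanges the carboxy group for a tetrazolyl group. Compound 4 is therefore expected to reach a similar maximal response, with a step of a number 5 percentage points lower from compound 2 to compound 4 (within the scatter). The estimate for compound 4 is 97%, within a range from 80% to 110%.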

Compound 4, largest response reached (reported as efficacy), in percent of the reference or control that the assay uses: 101%
Estimate against measurement, compound 4: 4 percentage points below, and the stated range covers the measured number.
By their numbers in this assay, from the lowest: compounds 3, 1, 4 and 2 (each within the scatter of the next).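

On the saturated ring carbon of the three-membered ring, 6-(1H-tetrazol-5-yl)pyridin-3-yl leaves the maximal response in this assay unseparated from that with 3-carboxyphenyl, with a number 1 percentage points lower from compound 2 to compound 4 (within the scatter) on changing both rings together. Among these compounds, the direct exchange of carboxy for 1H-tetrazol-5-yl on the pyridine ring, which the earlier compounds did not contain, gives no change at the digits printed from compound 1 to compound 4 (within the scatter) and shows that this read-out tolerates either group here. Nothing measured here accounts for this result.

As far as these compounds go, whether an amine or a primary amide could stand in place of the carboxylic acid remains open. So does the effect of a longer chain between the aromatic ring and the tetrazolyl group.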